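Anilino Variation on a Sulfonamide-Tailed Quinazoline Scaffold

The source may report more compounds than this note shows. Statements on the series, on what has been measured and on what is new or still open speak of the compounds shown alone.

Two compounds share a core that carries a five-carbon tether to a sulfonamide-bearing anilide. Compound 1 `COc1cc2ncnc(Nc3cccc(F)c3)c2cc1OCCCCC(=O)Nc1ccc(S(N)(=O)=O)cc1` gives 29900 nM in a functional assay on A-431 cells (Homo sapiens) for antiproliferative activity, read by MTT assay, with a stated time of 72 h; a lower number here means a stronger inhibitor, a higher number a weaker inhibitor. Compound 2 `COc1cc2ncnc(Nc3ccc(OC(F)(F)F)cc3)c2cc1OCCCCC(=O)Nc1ccc(S(N)(=O)=O)cc1` gives 22500 nM in this assay, and its number differs from compound 1 only by a 1.3-fold lower number from compound 1 to compound 2 (0.12 log units; within the scatter), so the two stand together within the scatter. Compound 3 `COc1cc2ncnc(Nc3cc(F)c(F)c(F)c3)c2cc1OCCCCC(=O)Nc1ccc(S(N)(=O)=O)cc1` differs from compound 2 by 3,4,5-trifluorophenyl in place of 4-(trifluoromethoxy)phenyl on a nitrogen on an aromatic ring. Within the data shown here, the only measured step, a 1.3-fold lower number from compound 1 to compound 2 (0.12 log units; within the scatter), also alters this aryl group and stayed within the scatter, so a step of a 1.1-fold higher number from compound 2 to compound 3 (0.05 log units; within the scatter) is expected, with no movement beyond the scatter. Compound 3 is therefore estimated at 25000 nM, between 10000 nM and 60000 nM.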

Compound 3, half-maximal inhibitory concentration: 23400 nM
For compound 3 the middle estimate is 1.1-fold (0.03 log units) above the measured one, within the range that was stated.
By their numbers in this assay, from the lowest: compounds 2, 3 and 1 (each within the scatter of the next).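

In this assay, the step to the 3,4,5-trifluorophenyl group is a 1.0-fold higher number from compound 2 to compound 3 (0.02 log units; within the scatter), and the same group set against 3-fluorophenyl gives a 1.3-fold lower number from compound 1 to compound 3 (0.11 log units; within the scatter). Thus a third aryl group on this nitrogen, one without the oxygen of 4-(trifluoromethoxy)phenyl, also leaves the number within the scatter, so all three compounds remain indistinguishable here. No measurement is at hand that would explain this insensitivity. The compounds shown leave open whether an amine or a carboxylic acid on this aryl ring, or a longer chain in the tether, would move the number beyond the scatter.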